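Methyl in Place of Fluoro: What to Expect for Compound 3

The compounds below may be only part of what the source reports. "The series", "measured", "known", "first", "only" and "open" are said of these compounds alone.

compound 1 `COc1ccn2c(-c3ccc(NC(=O)c4ccc([N+](=O)[O-])o4)cc3)cnc2c1`: 860 nM
compound 2 `COc1ccn2c(-c3ccc(NC(=O)c4ccc([N+](=O)[O-])o4)cc3F)cnc2c1`: 1080 nM

In a functional assay on MGC-803 cells (Homo sapiens) for antiproliferative activity, read by CCK-8 assay, with a stated time of 72 h (a higher number here means a weaker inhibitor, a lower number a stronger inhibitor), compound 1 gives 860 nM, while compound 2 gives 1080 nM. Compound 2 holds the higher of the two numbers, yet the step of a 1.3-fold higher number from compound 1 to compound 2 (0.10 log units; within the scatter) lies within the scatter. Compound 3 `COc1ccn2c(-c3ccc(NC(=O)c4ccc([N+](=O)[O-])o4)cc3C)cnc2c1` carries methyl in place of fluoro on an aromatic carbon. Within the data shown here, the only measured step, a 1.3-fold higher number from compound 1 to compound 2 (0.10 log units; within the scatter), touched the same aromatic carbon with a different exchange and stayed within the scatter, so in this assay no step beyond the scatter is expected here either. The step expected from this change is a 1.1-fold higher number from compound 2 to compound 3 (0.05 log units; within the scatter). Compound 3 is therefore estimated at 1200 nM, with a range from 500 nM to 3000 nM.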

Compound 3, half-maximal inhibitory concentration: 1030 nM
Beside the measured number, compound 3's estimate is 1.2-fold (0.07 log units) above it, within the range that was stated.
By their numbers in this assay, from the lowest: compounds 1, 3 and 2 (each within the scatter of the next).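

In this assay, methyl in place of fluoro gives a 1.0-fold lower number from compound 2 to compound 3 (0.02 log units; within the scatter), and methyl in place of hydrogen gives a 1.2-fold higher number from compound 1 to compound 3 (0.08 log units; within the scatter). This aromatic carbon, ortho to a large group and meta to a large group, has thus taken hydrogen, fluoro and methyl with no step beyond the scatter, and methyl shows that a carbon group leaves the number as flat as fluoro did. Nothing available bears on why these numbers stay so close. Still open, on these data alone, is whether a longer chain, an amine or a carboxylic acid on this carbon would move the number beyond the scatter. The three compounds also leave open whether this holds when the rest of the shared core is changed.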